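This account rests on a few compounds, and the source may have more. Where it says the series, first, only, none or still open, it means among the compounds named here.

Compound 1 `Cc1cc(CO)nc(NNC(=O)Nc2cc(Cl)nc(Cl)c2)c1` in a functional assay on CHO cells for antagonist activity at sphingosine 1-phosphate receptor 2 (Homo sapiens), read by fluorescence and calcium flux, with a stated time of 3 min (on this read-out lower numbers stand for stronger inhibition and higher numbers for weaker inhibition), gives a value that is a limit of the assay, > 6600 nM. Compound 2 `Cc1cc(NNC(=O)Nc2cc(Cl)nc(Cl)c2)nc(C(=O)N(C)C)c1` likewise gives only a limit in this assay, > 19000 nM. Among the measured compounds shown here, the one measured step between single-point variants, a step that the two limits leave unreadable from compound 1 to compound 2, cannot be read because both of its ends sit at limits the limit of > 6600 nM in this assay, at which 1 of the 3 values shown sits (the limit of > 19000 nM in this assay, at which 1 of the 3 values shown sits). For the measured compounds named here, compound 3 `CCOc1cc(NC(=O)NCc2cc(C)c(-c3cn(C)nc3C(F)(F)F)nn2)cc(C#N)n1` is the only member of the set with a number rather than a limit: in this assay compound 3 gives 11000 nM, weak in absolute terms but the only anchor for a numeric expectation. Compound 4 `CCOc1nc(Cl)cc(NC(=O)NCc2cc(C)c(-c3cn(C)nc3C(F)(F)F)nn2)c1C` differs from compound 3 in one place: 6-chloro-2-ethoxy-3-methylpyridin-4-yl in place of 2-cyano-6-ethoxypyridin-4-yl on an amide-type nitrogen. Going by the values given here, no measured step concerns this exchange, and the single measured step is unreadable, so there is no basis to expect a change beyond the usual scatter. The estimated step is therefore no change at the digits printed from compound 3 to compound 4 (within the scatter), none beyond the scatter. Compound 4 is expected at 11000 nM, with a range of 2500 nM to 50000 nM, and a fair chance that only a limit is reported.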

Compound 4, half-maximal inhibitory concentration: 8800 nM
Estimate against measurement, compound 4: 1.3-fold (0.10 log units) above; measured number inside the range.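

In this assay, among the compounds shown here, 6-chloro-2-ethoxy-3-methylpyridin-4-yl in place of 2-cyano-6-ethoxypyridin-4-yl on the amide-type nitrogen gives a 1.3-fold lower number from compound 3 to compound 4 (0.10 log units; within the scatter), the first step that can be read. For the compounds shown here, the place therefore tolerates this exchange, in which the nitrile leaves, chlorine and methyl enter and the ethoxy stays, without a shift beyond the scatter, and the earlier compounds could not show this. Nothing measured here bears on why the two values stay so close.

The exchange alters several ring substituents at once, so the contribution of the nitrile, the chlorine and the methyl cannot be separated, and the step between the two earlier compounds cannot be read. Going by these compounds, whether a carboxylic acid or an amine on this ring would move the value beyond the scatter stays open.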